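The source may hold more compounds than are shown below. What is called first, only, known or untested is meant among the compounds shown, and "the series" means these compounds.

Measured in a functional assay on HepG2 cells (Homo sapiens) for antiproliferative activity, read by MTT assay, with a stated time of 72 h; on this read-out higher numbers stand for weaker inhibition and lower numbers for stronger inhibition:
compound 1 `CC(C)N1C(=O)COc2ccc(-c3cccc(NS(=O)(=O)c4ccc(F)cc4)c3)cc21`: > 40000 nM, a limit of the assay
compound 2 `O=C1COc2ccc(-c3cccc(NS(=O)(=O)c4ccc(F)cc4)c3)cc2N1C1CC1`: > 40000 nM, a limit of the assay

Compound 2 has no numerical value, only its limit of > 40000 nM. Among the compounds with values here, the series so far stands at the limit of > 40000 nM in this assay, at which 2 of the 2 values shown sit. Compound 3 `COc1ccc(N2C(=O)COc3ccc(-c4cccc(NS(=O)(=O)c5ccc(F)cc5)c4)cc32)cc1` carries 4-methoxyphenyl in place of cyclopropyl on the amide-type nitrogen in a ring: 4-methoxyphenyl in place of cyclopropyl on an amide-type nitrogen in a ring. Within the data shown here, the one measured step at this nitrogen is a step that the two limits leave unreadable from compound 1 to compound 2, so it offers no size to carry over to the new group. With both measured compounds at the limit, compound 3 is expected to stay weak in this assay, and it may well report only a limit too. The expected change is small, an at least 1.1-fold lower number from compound 2 to compound 3 (0.05 log units; that floor lies within the scatter), with no clear direction beyond the scatter. For compound 3 the estimated value is 35000 nM, with an expected range from 12000 nM to 60000 nM.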

Compound 3, half-maximal inhibitory concentration: 29800 nM
Estimate against measurement, compound 3: 1.2-fold (0.07 log units) above; the range from low to high includes it.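

In this assay, compound 3 is the only compound shown with a numerical value, so 4-methoxyphenyl on this amide-type nitrogen gives a reading inside the range of the assay, which neither cyclopropyl nor isopropyl gave. The change from cyclopropyl reads as an at least 1.3-fold lower number from compound 2 to compound 3 (0.12 log units; that floor lies within the scatter), and the change from isopropyl reads as an at least 1.3-fold lower number from compound 1 to compound 3 (0.12 log units; that floor lies within the scatter); both are floors only, so they fix no true size and do not show a change beyond the scatter. The series as a whole still rests mostly on a limit: the limit of > 40000 nM in this assay, at which 2 of the 3 values shown sit.

The compounds shown leave open whether the measurable value goes with the aromatic ring itself or with its methoxy group, a question that a plain phenyl on this nitrogen would address. They also leave open how a longer chain, such as n-butyl, would read at this position.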